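Same Atoms, Joined Differently: A Triazole Swap

This account rests on a few compounds, and the source may have more. Where it says the series, first, only, none or still open, it means among the compounds named here.

In an ADME assay on NIH3T3 cells (Mus musculus) for cytotoxicity (a lower number here means that less compound is needed, a higher number that more compound is needed for the effect), compound 3 (`Cc1cc(Oc2cccc(Cn3ccnn3)c2)cc(C)c1Cl`) gives 66800 nM. Compound 1 (`c1ccc(-c2cccc(Oc3cccc(Cn4ccnc4)c3)c2)cc1`) gives 34000 nM, and these two values lie within the scatter of each other. Compound 2 (`c1ccc(Oc2cccc(Cn3ccnc3)c2)cc1`) gives only a limit of this assay, > 100000 nM. Compound 4 (`Cc1cc(Oc2cccc(Cn3nccn3)c2)cc(C)c1Cl`) has the same atoms as compound 3, joined differently: 2H-1,2,3-triazol-2-yl in place of 1H-1,2,3-triazol-1-yl on a saturated chain carbon bound to an aromatic carbon. Going by the values given here, the only measured step, an at least 2.9-fold higher number from compound 1 to compound 2 (0.46 log units; beyond the scatter), is modest but beyond the scatter; it puts hydrogen in place of phenyl and does not touch the triazole, so it bears only weakly on this change. No step beyond the scatter is expected, and the estimated change is a 1.1-fold lower number from compound 3 to compound 4 (0.05 log units; within the scatter). For compound 4, the expected value is 60000 nM, with an estimated range of 30000 nM to 100000 nM.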

Compound 4, half-maximal effective concentration: > 100000 nM
Compound 4: a limit, no number; the forecaster's own chance of this, stated with the estimate: 20%; at least 1.6-fold (0.22 log units) between middle value and limit.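

Going by these compounds alone, this is the first direct comparison of the two ways of joining the triazole to the saturated chain carbon, and in this assay the swap gives an at least 1.4-fold higher number from compound 3 to compound 4 (0.17 log units; that floor lies within the scatter). The value of compound 4 is a limit and not a number, so only a floor for this step can be read, and that floor does not separate the two triazoles. What can be read here is bounded by the assay itself: the limit of > 100000 nM in this assay, at which 2 of the 4 values shown sit.

On these data alone, how far the true value of compound 4 lies from its limit stays open. So does what a carboxylic acid or an amine in place of the triazole on that saturated chain carbon would give.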